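A bromine variant of the hydroxyphenyl hydrazone

This account rests on a few compounds, and the source may have more. Where it says the series, first, only, none or still open, it means among the compounds named here.

Compound 3 `Cc1c(C(=O)N/N=C\c2cc(F)ccc2O)oc2cccc(O)c12` carries a 5-fluoro-2-hydroxyphenyl on the carbon double-bonded to nitrogen, and in a functional assay on PC-3 cells (Homo sapiens) for inhibition (a lower number here means a stronger inhibitor, a higher number a weaker inhibitor), compound 3 gives 3170 nM, the lowest number among the three measured compounds. Its nearest neighbour is compound 1 `Cc1c(C(=O)N/N=C\c2cccc(F)c2O)oc2cccc(O)c12`, which gives 12700 nM; the step of a 4.0-fold lower number from compound 1 to compound 3 (0.60 log units; beyond the scatter) separates the two. Compound 2 `Cc1c(C(=O)N/N=C\c2ccccc2)oc2cccc(O)c12`, with a bare phenyl, gives 29200 nM; the steps of a 2.3-fold higher number from compound 1 to compound 2 (0.36 log units; beyond the scatter) and a 9.2-fold lower number from compound 2 to compound 3 (0.96 log units; beyond the scatter) place it furthest from compound 3.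

Compound 4 `Cc1c(C(=O)N/N=C\c2cccc(Br)c2O)oc2cccc(O)c12` differs from compound 3 by 3-bromo-2-hydroxyphenyl in place of 5-fluoro-2-hydroxyphenyl on a carbon with a double bond to nitrogen. Among the measured compounds shown here, the 3-bromo-2-hydroxyphenyl of compound 4 matches the 3-fluoro-2-hydroxyphenyl of compound 1 except that bromine stands in place of fluorine, so the step of a 4.0-fold lower number from compound 1 to compound 3 (0.60 log units; beyond the scatter) bears on it most directly; no measured step shows the exchange of bromine for fluorine itself. Because the step of a 4.0-fold lower number from compound 1 to compound 3 (0.60 log units; beyond the scatter) was modest and beyond the scatter, the reverse change is expected to give a modestly higher number in this assay, as a 2.8-fold higher number from compound 3 to compound 4 (0.45 log units; beyond the scatter). Compound 4 is therefore expected to give about 9000 nM, within a range of 3000 nM to 30000 nM.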

Compound 4, half-maximal inhibitory concentration: 16600 nM
Beside the measured number, compound 4's estimate is 1.8-fold (0.27 log units) below it; measured number inside the range.
By their numbers in this assay, from the lowest: compound 3; then compounds 1, 4 and 2 (each within the scatter of the next, the first and the last beyond it).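

In this assay, the exchange of fluoro for bromo on an aromatic carbon can now be read directly, and it stays within the scatter, with a 1.3-fold higher number from compound 1 to compound 4 (0.12 log units; within the scatter). The 3-bromo-2-hydroxyphenyl of compound 4 is also not separated from the bare phenyl of compound 2, with a 1.8-fold lower number from compound 2 to compound 4 (0.25 log units; within the scatter). The step from the 5-fluoro-2-hydroxyphenyl, by contrast, lies beyond the scatter, with a 5.2-fold higher number from compound 3 to compound 4 (0.72 log units; beyond the scatter), so compound 3 keeps the lowest number of the four, and the change of halogen on the 3-substituted ring does not bring compound 1 or compound 4 near it.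

No measurement here accounts for these differences. As far as these compounds go, whether a chlorine, a methoxy group or an amine in place of the halogen would reach the number of compound 3 remains open.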